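The source may report more compounds than this note shows. Statements on the series, on what has been measured and on what is new or still open speak of the compounds shown alone.

Compound 1 `C[Se]/C(=N\C(=O)c1ccco1)NC(=O)c1ccco1`: 760 nM
Compound 2 `CS/C(=N\C(=O)c1ccco1)NC(=O)c1ccco1`: > 100000 nM
Compound 3 `CS/C(=N\C(=O)c1cc(-c2ccccc2)nc2ccccc12)NC(=O)c1cc(-c2ccccc2)nc2ccccc12`: 6240 nM

All three were tested in a functional assay on HepG2 cells (Homo sapiens) for cytotoxicity, read by MTT assay, with a stated time of 72 h; on this read-out higher numbers stand for weaker inhibition of growth and lower numbers for stronger inhibition of growth. Compound 1 gives 760 nM. For compound 2 the value of > 100000 nM is a limit of the assay, not a number. Compound 3 gives 6240 nM. Compound 2 and compound 1 differ in one place: a group of 2 heavy atoms (1 carbon, 1 selenium; no ring) in place of a group of 2 heavy atoms (1 carbon, 1 sulfur; no ring), on a carbon with a double bond to nitrogen. From the compounds shown here alone, that change brought an at least 130-fold lower number from compound 2 to compound 1 (2.11 log units; beyond the scatter), and its full size stays open because of the limit of > 100000 nM in this assay, at which 1 of the 3 values shown sits. Compound 4 `C[Se]/C(=N\C(=O)c1cc(-c2ccccc2)nc2ccccc12)NC(=O)c1cc(-c2ccccc2)nc2ccccc12` differs from compound 3 in the same way: a group of 2 heavy atoms (1 carbon, 1 selenium; no ring) in place of a group of 2 heavy atoms (1 carbon, 1 sulfur; no ring), on a carbon with a double bond to nitrogen. How the core of compound 3 differs from the core of compound 2 is not broken down here. The change being the same, a step in the same direction is expected, and the expected step is a 21-fold lower number from compound 3 to compound 4 (1.32 log units; beyond the scatter), kept smaller than the earlier one, which rests on a limit. Compound 4 is therefore estimated at 300 nM, expected between 40 nM and 2000 nM.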

Compound 4, concentration for 50% growth inhibition: 4540 nM
Compound 4: middle estimate off by 15-fold (1.18 log units), on the low side; the whole stated range lies below it.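

In this assay, putting selenium in place of the sulfur of the methylsulfanyl group on the core of compound 3 gave a 1.4-fold lower number from compound 3 to compound 4 (0.14 log units; within the scatter), so on this core the swap shows no measurable effect. The large step seen on the other core did not carry over, which shows that the size of this change depends on the core that carries it: the same change on two cores in this assay, an at least 130-fold lower number (2.11 log units; beyond the scatter) from compound 2 to compound 1 and a 1.4-fold lower number (0.14 log units; within the scatter) from compound 3 to compound 4, at least 95-fold (1.98 log units) apart, beyond the scatter of two such steps. From the compounds shown here alone, what stays unknown is the full size of the earlier step, since compound 2 sits at a limit of the assay: the limit of > 100000 nM in this assay, at which 1 of the 4 values shown sits.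

Which part of the two cores decides the size of the step remains open. So does what an ethyl group in place of the methyl on selenium would do on either core.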